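Hemolysis notes on a bis-amidine series

This account rests on a few compounds, and the source may have more. Where it says the series, first, only, none or still open, it means among the compounds named here.

Measured so far:
- compound 1 `N=C(N)c1ccc(-c2ccc(-c3ccccc3)s2)s1`: "non-toxic" (no number reported)
- compound 2 `N=C(N)c1ccc(-c2ccc(-c3ccc(Cl)cc3)o2)o1`: 14%

In an ADME assay on cells (Erythrocyte, Homo sapiens) for activation, read by hemolysis, with a stated time of 30 min, tested at 1.25 mM (a lower number here means a weaker effect, a higher number a stronger effect of the compound at the concentration tested), compound 1 is reported only as "non-toxic" (no number reported); no single number stands for it, so its place on the scale cannot be fixed beyond a weak effect. Among the measured compounds shown here, compound 2 `N=C(N)c1ccc(-c2ccc(-c3ccc(Cl)cc3)o2)o1` gives 14% in this assay, a low reading, and no step between compound 1 and compound 2 is known.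

Compound 3 `N=C(N)c1ccc(-c2ccc(-c3ccc(Cl)cc3)s2)s1` is not yet measured. It differs from compound 1 by chloro in place of hydrogen on an aromatic carbon. For the measured compounds named here, no measured step covers this change here. With compound 1 described as non-toxic and compound 2 low, the expectation for compound 3 in this assay is a step of no more than the usual scatter, with no clear direction. Compound 3 is therefore expected to read about 10%, within 0% to 30%.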

Compound 3, a percentage reported as activity, at one concentration (the size of the read-out at that concentration, not a potency): "non-toxic" (no number reported)
Compound 3 has no reported number here; no gap can be computed for the estimate.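

In this assay, among the compounds shown here, compound 1 gives "non-toxic" (no number reported) and compound 3 gives "non-toxic" (no number reported) with no number for either, so no step between them can be read. The compounds shown leave open how far chloro in place of hydrogen shifts the reading in this assay on a numeric scale. No evidence bears on this result.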